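Aminochalcone pyrazoles: removing one methoxy from compound 2

A few compounds are considered here, and "the series" means these few. Any claim that something is new, unique, unknown or untested is made for them only; others in the source may bear on it.

Measured so far:
- compound 1 `COc1ccc(-c2cc(/C=C/C(=O)c3ccc(N)cc3)[nH]n2)cc1`: -51%
- compound 2 `COc1cc(-c2cc(/C=C/C(=O)c3ccc(N)cc3)[nH]n2)cc(OC)c1OC`: -65%
- compound 3 `COc1ccc(C(=O)/C=C/c2cc(-c3cc(OC)c(OC)c(OC)c3)n[nH]2)cc1`: -78%

In a functional assay on MDA-MB-468 cells (Homo sapiens) for cytotoxicity, read by sulforhodamine B assay, with a stated time of 48 h, tested at 100 uM (on this read-out lower numbers stand for a stronger effect and higher numbers for a weaker effect at the one concentration tested), compound 2 gives -65%, the second highest of the three numbers; compound 3 sits nearest, compound 1 furthest. Among the measured compounds shown here, the only single-site step measured is a number 13 percentage points lower from compound 2 to compound 3 (beyond the scatter), which concerns the amino end and does not bear on the change considered here. Compound 4 `COc1ccc(-c2cc(/C=C/C(=O)c3ccc(N)cc3)[nH]n2)cc1OC` differs from compound 2 by hydrogen in place of methoxy on an aromatic carbon. Compound 1, carrying a single methoxy, gives -51%, and compound 2 with three gives -65%; compound 4 lies structurally between them, so an intermediate value is expected, a modest step up as a number 7 percentage points higher from compound 2 to compound 4 (within the scatter). Compound 4 is therefore estimated at -58%, within -72% to -44%.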

Compound 4, a percentage reported as activity, at one concentration (the size of the read-out at that concentration, not a potency): -73%
For compound 4 the middle estimate is 15 percentage points above the measured one, and the stated range ends above it.
By their numbers in this assay, from the lowest: compounds 3, 4 and 2 (each within the scatter of the next, the first and the last beyond it); then compound 1.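

In this assay, hydrogen in place of the methoxy leaves compound 2 and compound 4 indistinguishable (a number 8 percentage points lower from compound 2 to compound 4 (within the scatter)), so this methoxy adds nothing readable. Adding a methoxy to compound 1 does give a readable step (a number 22 percentage points lower from compound 1 to compound 4 (beyond the scatter)), so the effect of added methoxy groups is not even across the series: the step from compound 1 to compound 4 is readable, and the one from compound 4 to compound 2 is not. Nothing available explains this difference.

Going by these compounds, it remains open whether a hydroxy group or an ethoxy group at this place would behave like methoxy or like hydrogen. On these data alone, it is also open whether the same holds when methoxy replaces amino, as in compound 3.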